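The compounds below may be only part of what the source reports. "The series", "measured", "known", "first", "only" and "open" are said of these compounds alone.

Working notes on the series. Compound 1 `COc1cc(N)c(Cl)cc1NC(=O)C1CCN(C/C=C/c2ccccc2)CC1` carries 2-phenylethenyl on a saturated chain carbon bound to an amine nitrogen in a ring; compound 2 `COc1cc(N)c(Cl)cc1NC(=O)C1CCN(CC2CCC2)CC1` carries cyclobutyl at that place and compound 3 `CCN1CCC(C(=O)Nc2cc(Cl)c(N)cc2OC)CC1` methyl. All three share one core.

In a functional assay on the whole organism for antagonist activity, with Mus musculus as the target (on this read-out higher numbers stand for an effect only at larger amounts of compound and lower numbers for an effect already at smaller amounts), compound 1 returns only a limit, > 10 mg/kg. Compound 2 likewise returns only a limit in this assay, > 10 mg/kg. Compound 3 too reaches only a limit in this assay, > 10 mg/kg. Accordingly the steps a step that the two limits leave unreadable from compound 1 to compound 2, a step that the two limits leave unreadable from compound 1 to compound 3 and a step that the two limits leave unreadable from compound 2 to compound 3 cannot be sized; every value shown sits at the limit of > 10 mg/kg in this assay, at which 3 of the 3 values shown sit. Compound 2 therefore stands at no number, only at the same limit as the rest of the series.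

The next member is compound 4 `COc1cc(N)c(Cl)cc1NC(=O)C1CCN(Cc2ccc(F)cc2)CC1`, reached from compound 2 by the change (4-fluorophenyl in place of cyclobutyl on a saturated chain carbon bound to an amine nitrogen in a ring). None of the three measured steps carries a readable size, so no direction and no magnitude can be drawn from them for this assay. Compound 4 is expected most likely to return a limit again, and as a number the estimate for compound 4 is 15 mg/kg with a range from 5 mg/kg to 50 mg/kg. The change is accordingly estimated to read a step that the limit leaves unreadable from compound 2 to compound 4, with no shift beyond the scatter expected.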

Compound 4, dose for half-maximal effect: 0.6 mg/kg
For compound 4 the middle estimate is 25-fold (1.40 log units) above the measured one; measured number outside the range, below it.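

Working notes, continued. In this assay the place on a saturated chain carbon bound to an amine nitrogen in a ring now gives its first readable steps: 4-fluorophenyl in place of cyclobutyl gives an at least 16-fold lower number from compound 2 to compound 4 (1.22 log units; beyond the scatter) and in place of methyl gives an at least 16-fold lower number from compound 3 to compound 4 (1.22 log units; beyond the scatter) in the same direction. An aromatic ring at this place is not sufficient by itself, and compound 1 goes against any such pattern, with 4-fluorophenyl in place of 2-phenylethenyl giving an at least 16-fold lower number from compound 1 to compound 4 (1.22 log units; beyond the scatter) as its step. The steps among the other three compounds remain unreadable, and each new step gives only a minimum size, not a measured gap: (the limit of > 10 mg/kg in this assay, at which 3 of the 4 values shown sit)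

The compounds shown do not separate the contribution of the fluorine from that of the six-membered aromatic ring, a question that a plain phenyl or a 4-chlorophenyl at this place would address. They also leave open whether a longer chain between the amine nitrogen and the 4-fluorophenyl keeps the number of compound 4, and how far compound 1, compound 2 and compound 3 lie beyond their shared limit.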